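The source may report more compounds than this note shows. Statements on the series, on what has been measured and on what is new or still open speak of the compounds shown alone.

Measured so far in an assay on isolated protein for inhibition of Rho-associated protein kinase 1 (Homo sapiens), tested at 30 uM; a lower number here means less inhibition, a higher number more inhibition at the concentration tested (going by the name of the read-out):
Compound 1, `Fc1ccc(Cn2cnc3ncnc(Cl)c32)cc1`, gives 7%.
Compound 2, `Nc1ncnc2ncn(Cc3ccc(F)cc3)c12`, gives 6%.

Compound 2 holds the lower of the two numbers measured, but its nearest neighbour is compound 1 and the step of a number 1 percentage points lower from compound 1 to compound 2 (within the scatter) is inside the scatter, so no order between the two can be read.

The next compound, compound 3, `COc1ncnc2ncn(Cc3ccc(F)cc3)c12`, differs from compound 2 in one place: methoxy in place of amino on an aromatic carbon. Going by the values given here, the only measured step that touches this carbon is the one from compound 1 to compound 2, a number 1 percentage points lower from compound 1 to compound 2 (within the scatter), an exchange at the same position that left this assay essentially unchanged. Among the compounds with values here, no step with a methoxy group has been measured. On that basis the step from compound 2 to compound 3 is expected to stay within the scatter, with an expected change of a number 1 percentage points higher from compound 2 to compound 3 (within the scatter). Compound 3 is therefore estimated at 7%, in a range from 0% to 18%.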

Compound 3, a percentage reported as inhibition, at one concentration (the size of the read-out at that concentration, not a potency): 1%
Beside the measured number, compound 3's estimate is 6 percentage points above it, and the stated range covers the measured number.
By their numbers in this assay, from the lowest: compounds 3, 2 and 1 (each within the scatter of the next).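

In this assay the exchange at this aromatic carbon now reaches a group with an oxygen link, and the step runs a number 5 percentage points lower from compound 2 to compound 3 (within the scatter) and a number 6 percentage points lower from compound 1 to compound 3 (within the scatter) and so gives no order among the three groups. Amino has a hydrogen-bond donor and methoxy has none, and chloro and methoxy are also far apart as groups, yet neither exchange moves the number beyond the scatter, so at this single test concentration the position has not yet shown any dependence on the group it carries. No supporting evidence bears on this result.

Going by these compounds, whether any group at this carbon can move the number beyond the scatter remains open. A dimethylamino group or a longer ether chain such as ethoxy would test that, and neither is among the compounds shown.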